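Replacing a Fluorophenyl Hydrazine with a Hydroxyethyl Hydrazine

The compounds below may be only part of what the source reports. "The series", "measured", "known", "first", "only" and "open" are said of these compounds alone.

Of the compounds shown here, three sharing one core have been tested in a functional assay on K562 cells (Homo sapiens) for inhibition; a higher number here means a weaker inhibitor of growth, a lower number a stronger inhibitor of growth. In this assay compound 1 `Nc1nn2c(O)cc(-c3ccccc3)nc2c1[N+](=O)[O-]` gives only a limit, > 50 ug/mL. Compound 2 `Nc1nn2c(O)cc(-c3ccc(F)cc3)nc2c1[N+](=O)[O-]` likewise gives only a limit in this assay, > 50 ug/mL. The step that the two limits leave unreadable from compound 1 to compound 2 is therefore unreadable. Going by the values given here, compound 3 `Nc1nn2c(O)cc(CNNc3ccc(F)cc3)nc2c1[N+](=O)[O-]` gives the only measured number in this assay, 19.7 ug/mL, while the other two values sit at the limit of > 50 ug/mL in this assay, at which 2 of the 3 values shown sit. Compound 4 `Nc1nn2c(O)cc(CNNCCO)nc2c1[N+](=O)[O-]` differs from compound 3 by 2-hydroxyethyl in place of 4-fluorophenyl on an amine nitrogen. Among the compounds with values here, no measured step bears on this change, since a step that the two limits leave unreadable from compound 1 to compound 2 touches another part of the molecule and is unreadable anyway. Compound 4 is therefore expected to show a step of a 1.5-fold higher number from compound 3 to compound 4 (0.18 log units; within the scatter), giving an estimate of 30 ug/mL with a range from 10 ug/mL to 60 ug/mL.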

Compound 4, concentration for 50% growth inhibition: > 50 ug/mL
Compound 4 was reported as a limit; the forecaster's own chance of this, stated with the estimate: 35%; middle value at least 1.6-fold (0.22 log units) away from the limit.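

On this amine nitrogen the group is not interchangeable: in this assay, 2-hydroxyethyl in place of 4-fluorophenyl gives an at least 2.5-fold higher number from compound 3 to compound 4 (0.40 log units; beyond the scatter), a weakening of growth inhibition beyond the scatter. Compound 4 is reported only as a limit, so this step is a minimum and its true size may be larger. The steps from compound 1 and from compound 2 to compound 4 cannot be read: the limit of > 50 ug/mL in this assay, at which 3 of the 4 values shown sit.

From the compounds shown here alone, it remains open whether a plain phenyl or a benzyl group on this nitrogen would keep the growth inhibition of compound 3. How a longer alkyl chain would behave there is also unknown.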